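Working notes: from compound 3 to compound 4

The source may report more compounds than this note shows. Statements on the series, on what has been measured and on what is new or still open speak of the compounds shown alone.

Compound 1 `Cc1cc(C(=O)Nc2ccccc2)nn1Cc1cc(Cl)ccc1OCc1ccccc1` gives 39.8 nM in an assay on CHO-K1 cells for displacement of a labelled ligand from prostaglandin E2 receptor EP1 subtype (Homo sapiens); on this read-out higher numbers stand for weaker inhibition and lower numbers for stronger inhibition. Compound 2 `Cc1cc(C(=O)Nc2c(F)cccc2F)nn1Cc1cc(Cl)ccc1OCc1ccccc1` gives 10 nM, a gain described by a 4.0-fold lower number from compound 1 to compound 2 (0.60 log units; beyond the scatter). Compound 3 `Cc1cc(NC(=O)C2CCCC2)nn1Cc1cc(Cl)ccc1OCc1ccccc1` gives 15.9 nM; the change from the anilide to the reversed amide is described by a 2.5-fold lower number from compound 1 to compound 3 (0.40 log units; beyond the scatter), while a 1.6-fold higher number from compound 2 to compound 3 (0.20 log units; within the scatter) stays within the scatter. Compound 3 therefore stands second highest of the three numbers, separated from compound 2 only within the scatter and from compound 1 beyond it.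

Compound 4 `Cc1cc(NC(=O)O[C@H]2CCOC2)nn1Cc1cc(Cl)ccc1OCc1ccccc1` differs from compound 3 in one place: (oxolan-3-yl)oxy in place of cyclopentyl on a carbonyl carbon. Going by the values given here, no measured step swaps the cyclopentyl for an oxygen-bearing ring; the steps that bear on it, a 2.5-fold lower number from compound 1 to compound 3 (0.40 log units; beyond the scatter) and a 1.6-fold higher number from compound 2 to compound 3 (0.20 log units; within the scatter), only show that exchanging the group on that aromatic carbon has so far shifted the number modestly in either sense. The step is expected to be small, a 1.6-fold higher number from compound 3 to compound 4 (0.20 log units; within the scatter), with no direction beyond the scatter claimed. Compound 4 is estimated at 25 nM, within 8 nM to 80 nM.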

Compound 4, half-maximal inhibitory concentration: 79.4 nM
Beside the measured number, compound 4's estimate is 3.2-fold (0.50 log units) below it; measured number inside the range.
By their numbers in this assay, from the lowest: compounds 2 and 3 (each within the scatter of the next); then compounds 1 and 4 (each within the scatter of the next).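

In this assay, going by these compounds alone, the group on this carbonyl carbon proves to matter more than the earlier compounds showed: with (oxolan-3-yl)oxy in place of cyclopentyl there is a 5.0-fold higher number from compound 3 to compound 4 (0.70 log units; beyond the scatter) in a single exchange. Within the data shown here, the advantage of compound 3 over compound 1 does not carry over to this group, as a 2.0-fold higher number from compound 1 to compound 4 (0.30 log units; within the scatter) stays within the scatter, while a 7.9-fold higher number from compound 2 to compound 4 (0.90 log units; beyond the scatter) is the widest step so far. No data on hand give a cause for these steps.

The compounds shown do not separate the oxygen that links the ring to the carbonyl from the oxygen inside the ring, which cyclopentyloxy or a directly attached oxolan-3-yl would tell apart. Going by these compounds, the opposite stereocentre of the oxolan-3-yl group and an open chain such as isopropoxy on the same carbonyl also remain open.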